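The source may hold more compounds than are shown below. What is called first, only, known or untested is meant among the compounds shown, and "the series" means these compounds.

In a functional assay on DU-145 cells (Homo sapiens) for inhibition, read by trypan blue exclusion, with a stated time of 96 h (a lower number here means a stronger inhibitor of growth, a higher number a weaker inhibitor of growth), compound 1 `O=C(/C(=C\c1ccc(O)cc1)SCc1ccc(Cl)cc1)c1ccc(Br)cc1` gives 10000 nM. Compound 2 `COc1cc(/C=C(/Sc2ccc(Br)cc2)C(=O)c2ccc(Br)cc2)ccc1F` stands level with it at 10000 nM, a gap within the usual scatter. Compound 3 `CN(C)c1ccc(/C=C(/Sc2ccccc2Br)C(=O)c2ccc(Br)cc2)cc1` reaches only a limit of the assay, > 100000 nM.

Compound 4 `O=C(/C(=C\c1cc(Cl)cc(Cl)c1Cl)SCc1ccc(Cl)cc1)c1ccc(Br)cc1` has not yet been measured. It keeps the core of compound 1 but carries 2,3,5-trichlorophenyl in place of 4-hydroxyphenyl on a double-bonded chain carbon bound to a double-bonded chain carbon.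

The three measured compounds differ from one another in more than one place, so none of them shows the size of this single change. The expectation in this assay is therefore tentative: a moderate step toward stronger growth inhibition, with a result within the scatter of compound 1 still quite possible. The expected change is a 3.3-fold lower number from compound 1 to compound 4 (0.52 log units; beyond the scatter). For compound 4, the estimated value is 3000 nM, with an expected range from 300 nM to 30000 nM.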

Compound 4, concentration for 50% growth inhibition: 1000 nM
Estimate against measurement, compound 4: 3.0-fold (0.48 log units) above, within the range that was stated.
By their numbers in this assay, from the lowest: compound 4; then compounds 1 and 2 (each within the scatter of the next). At a limit, above all of these: compound 3.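

In this assay, within the data shown here, exchanging the 4-hydroxyphenyl group for a 2,3,5-trichlorophenyl group gives a 10-fold lower number from compound 1 to compound 4 (1.00 log units; beyond the scatter), the first change in a single place that can be read in this set. It shows that the group at this place can move growth inhibition beyond the usual scatter, with the rest of the structure held constant. Nothing measured here explains why this change has this effect.

As far as these compounds go, it remains open how a plain phenyl, a phenyl with a single chlorine or a phenyl with a carboxylic acid would compare at this place, so the loss of the hydroxyl and the gain of the chlorines cannot yet be separated. From the compounds shown here alone, whether the same exchange would act alike on the structure of compound 2 also remains open.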